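From Hexyl to 1-Phenylethyl on an Amide Nitrogen

The source may report more compounds than this note shows. Statements on the series, on what has been measured and on what is new or still open speak of the compounds shown alone.

Of the compounds shown here, three sharing one core have been measured in a functional assay on HL-60 cells (Homo sapiens), with a stated time of 2 days; a higher number here means a weaker inhibitor, a lower number a stronger inhibitor. Compound 1 `O=C(NC1CCCCC1)c1nc[nH]c1C(=O)Nc1ccc(Cl)c(Cl)c1` gives 33100 nM, compound 2 `CCCCCCNC(=O)c1[nH]cnc1C(=O)Nc1ccc(Cl)c(Cl)c1` gives 14600 nM, and compound 3 `O=C(NCc1ccc(-c2ccccc2)cc1)c1nc[nH]c1C(=O)Nc1ccc(Cl)c(Cl)c1` gives 7000 nM. Compound 2 therefore holds the middle place, with the second highest of the three numbers, and its gaps to compound 1 and compound 3 both lie only just beyond the scatter.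

Compound 4 `C[C@@H](NC(=O)c1[nH]cnc1C(=O)Nc1ccc(Cl)c(Cl)c1)c1ccccc1` has not yet been measured in this assay. It differs from compound 2 by 1-phenylethyl in place of hexyl on an amide-type nitrogen, with 1-phenylethyl in place of hexyl on an amide-type nitrogen. Going by the values given here, no measured pair shows a change in one place, so the expectation rests on the narrow spread of the three numbers, from compound 3 at 7000 nM to compound 1 at 33100 nM. No step beyond the scatter is expected, in either direction, and the estimated step is a 1.2-fold higher number from compound 2 to compound 4 (0.09 log units; within the scatter). Compound 4 is expected at 18000 nM, with an estimated range of 7000 nM to 45000 nM.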

Compound 4, half-maximal inhibitory concentration: 8800 nM
Compound 4: middle estimate off by 2.0-fold (0.31 log units), on the high side; the range from low to high includes it.
By their numbers in this assay, from the lowest: compounds 3, 4 and 2 (each within the scatter of the next, the first and the last beyond it); then compound 1.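

In this assay, going by these compounds alone, the exchange of hexyl for 1-phenylethyl gives a 1.7-fold lower number from compound 2 to compound 4 (0.22 log units; within the scatter) and provides the first reading of a change in one place. It shows that, on this amide-type nitrogen, an open chain can give way to a group carrying a six-membered aromatic ring of carbon only and a defined stereocentre with no step beyond the scatter. No measurement at hand accounts for this result or ties it to any property of either group.

The compounds shown leave open whether the mirror-image form of 1-phenylethyl would read the same as the form in compound 4. They also leave open how this nitrogen would tolerate a substituent bearing an amine or a carboxylic acid.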